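Acetamido in place of fluoro: expected cytotoxicity of compound 4

The source may report more compounds than this note shows. Statements on the series, on what has been measured and on what is new or still open speak of the compounds shown alone.

Measured so far:
compound 1, `Fc1ccc(-c2nc3cc(C(F)(F)F)ccc3[nH]2)cc1`: 19000 nM
compound 2, `CN1CCN(CC(=O)Nc2ccc(-c3nc4cc(C(F)(F)F)ccc4n3C)cc2)CC1`: 44000 nM
compound 3, `Cn1c(-c2ccc([N+](=O)[O-])cc2)nc2cc(C(F)(F)F)ccc21`: a limit, > 100000 nM

In an ADME assay on MDBK cells (Bos taurus) for cytotoxicity, read by MTT assay, with a stated time of 96 h (a lower number here means that less compound is tolerated, a higher number that more compound is tolerated), compound 1 gives 19000 nM, the lowest of the two numbers in hand, so among the compounds with a number it is the least tolerated. Compound 2, which carries an amide-linked side chain on the six-membered aromatic ring of carbon only and a methyl on the shared core, gives 44000 nM, a higher number that lies beyond the usual scatter. Compound 3 returns only a limit in this assay, > 100000 nM. One of the three values therefore sits at the limit of > 100000 nM in this assay, at which 1 of the 3 values shown sits.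

Compound 4, `CC(=O)Nc1ccc(-c2nc3cc(C(F)(F)F)ccc3[nH]2)cc1`, differs from compound 1 in one place: acetamido in place of fluoro on an aromatic carbon. Within the data shown here, no measured pair with this exact change is available, so the expectation rests on the neighbours only. Compound 2, the other amide-bearing member, giving 44000 nM points toward a higher number for an amide on that ring. The step from compound 1 is expected to be upward and of moderate size, a 2.1-fold higher number from compound 1 to compound 4 (0.32 log units; beyond the scatter), probably beyond the scatter but short of the limit. Compound 4 is therefore estimated at 40000 nM, with a range from 15000 nM to 100000 nM.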

Compound 4, half-maximal cytotoxic concentration: 50000 nM
Compound 4: the middle estimate sits 1.3-fold (0.10 log units) below what was measured; measured number inside the range.
By their numbers in this assay, from the lowest: compound 1; then compounds 2 and 4 (each within the scatter of the next). At a limit, above all of these: compound 3.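

In this assay, acetamido in place of fluoro on an aromatic carbon, para to a large group, gives a 2.6-fold higher number from compound 1 to compound 4 (0.42 log units; beyond the scatter). Among these compounds, this is the first step that isolates a single change at this position, and it is a modest one, though beyond the scatter. The position accepts an exchange of a single fluorine for the larger acetamido, which brings a hydrogen-bond donor and a hydrogen-bond acceptor, and the number moves upward, while compound 4 remains a measured number and not a limit, so the whole step can be read: the limit of > 100000 nM in this assay, at which 1 of the 4 values shown sits.

Going by these compounds, it remains open whether an amine or a carboxylic acid in the same place, or a longer chain on the amide carbonyl, would carry the number further up or would bring it back toward that of compound 1. One step also cannot show whether acetamido in place of fluoro would move the number by a similar amount on a core carrying a methyl, or whether the change depends on the rest of the molecule.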